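Swapping an Ethoxyphenyl for a Trifluoromethylphenyl

The source may hold more compounds than are shown below. What is called first, only, known or untested is meant among the compounds shown, and "the series" means these compounds.

Measured compounds:
compound 1 `COc1cccc(NC2=CC(=O)c3c(nc4n3[C@H]3OC[C@@H](O)[C@H]3OC4)C2=O)c1`: 3830 nM
compound 2 `CCOc1ccc(NC2=CC(=O)c3c(nc4n3[C@H]3OC[C@@H](O)[C@H]3OC4)C2=O)cc1`: > 4000 nM
compound 3 `CCOc1ccccc1NC1=CC(=O)c2c(nc3n2[C@H]2OC[C@@H](O)[C@H]2OC3)C1=O`: > 4000 nM

In a functional assay on MCF7 cells (Homo sapiens) for inhibition, read by sulforhodamine B assay (on this read-out lower numbers stand for stronger inhibition and higher numbers for weaker inhibition), compound 1 gives 3830 nM. For compound 2 this assay reports only a limit, > 4000 nM. For compound 3 this assay likewise returns a limit, > 4000 nM. Compound 3 therefore stands at the weak end of what is shown, at the limit of > 4000 nM in this assay, at which 2 of the 3 values shown sit, with no exact number of its own.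

The steps among these three are an at least 1.0-fold higher number from compound 1 to compound 2 (0.01 log units; that floor lies within the scatter) and an at least 1.0-fold higher number from compound 1 to compound 3 (0.01 log units; that floor lies within the scatter), while a step that the two limits leave unreadable from compound 2 to compound 3. All of them change only the substituent on the phenyl ring attached to the amine nitrogen, and none reaches beyond the scatter.

Compound 4 `O=C1C(Nc2ccc(C(F)(F)F)cc2)=CC(=O)c2c1nc1n2[C@H]2OC[C@@H](O)[C@H]2OC1` differs from compound 3 by 4-(trifluoromethyl)phenyl in place of 2-ethoxyphenyl on an amine nitrogen. Among the compounds with values here, no measured step involves a trifluoromethyl group, so the closest guides are the ring-substituent swaps, which all stayed at or near the limit. Compound 4 is expected to land near 4500 nM, within 1500 nM to 15000 nM, an estimated step that the limit leaves unreadable from compound 3 to compound 4 that is not expected to exceed the scatter.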

Compound 4, half-maximal inhibitory concentration: > 4000 nM
Compound 4 ended at the assay's limit; the forecaster's own chance of this, stated with the estimate: 55%; the middle value is on the limit's open side.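

In this assay, replacing an ethoxyphenyl group on this amine nitrogen with 4-(trifluoromethyl)phenyl, a group with no hydrogen-bond acceptor and no oxygen, still yields no exact number, so compound 4 reports only a limit. Within the data shown here, measured against the one exact value, the change gives an at least 1.0-fold higher number from compound 1 to compound 4 (0.01 log units; that floor lies within the scatter). The steps from compound 2 and from compound 3 to compound 4 cannot be read, as both ends of each are limits. Three different substituted phenyl groups at this nitrogen now share one ceiling: the limit of > 4000 nM in this assay, at which 3 of the 4 values shown sit.

As far as these compounds go, how far past that limit compounds 2, 3 and 4 lie, and in what order, stays unknown. Also open, from the compounds shown here alone, is whether a carboxylic acid or an amine on the phenyl ring, or a longer chain in its place, would bring the number down.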